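This account rests on a few compounds, and the source may have more. Where it says the series, first, only, none or still open, it means among the compounds named here.

In a functional assay on A2780 cells (Homo sapiens) for cytotoxicity (a lower number here means a stronger inhibitor, a higher number a weaker inhibitor), three compounds sharing one core have been measured. Compound 1 `CC(C)(C)c1cnc(CSc2cnc(NC(=O)OCc3ccccc3)s2)o1` gives 1040 nM, compound 2 `CCNC(=O)Nc1ncc(SCc2ncc(C(C)(C)C)o2)s1` gives 120 nM, and compound 3 `CC(C)(C)c1cnc(CSc2cnc(NC(=O)Nc3ccc(F)cc3)s2)o1` gives 900 nM. Compound 3 thus sits within the scatter of compound 1, and both stand clearly above compound 2.

Compound 4 `CC(C)(C)c1cnc(CSc2cnc(NC(=O)Nc3c(Cl)cccc3Cl)s2)o1` has not yet been measured. It keeps all of compound 3 except the group on an amide-type nitrogen: 2,6-dichlorophenyl in place of 4-fluorophenyl on an amide-type nitrogen.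

The closest evidence is a change at this same place, a 7.5-fold higher number from compound 2 to compound 3 (0.88 log units; beyond the scatter), which swaps ethyl for an aromatic ring. Two further steps change the neighbouring group: an 8.7-fold lower number from compound 1 to compound 2 (0.94 log units; beyond the scatter) and a 1.2-fold lower number from compound 1 to compound 3 (0.06 log units; within the scatter). None of these replaces one aromatic ring with another, so the data offer no direct guide. Both groups hold one six-membered aromatic ring of carbon only, so no change beyond the scatter is expected, though with real uncertainty. The estimated step is a 1.1-fold higher number from compound 3 to compound 4 (0.05 log units; within the scatter). For compound 4 the expected value is 1000 nM, with an estimated range from 300 nM to 3000 nM.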

Compound 4, half-maximal inhibitory concentration: 1500 nM
Beside the measured number, compound 4's estimate is 1.5-fold (0.18 log units) below it; the range from low to high includes it.
By their numbers in this assay, from the lowest: compound 2; then compounds 3, 1 and 4 (each within the scatter of the next).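

In this assay, among the compounds shown here, the first swap of one aromatic ring for another at this amide-type nitrogen gives a 1.7-fold higher number from compound 3 to compound 4 (0.22 log units; within the scatter) and so leaves 2,6-dichlorophenyl and 4-fluorophenyl indistinguishable here. With a second aromatic group in place, the result against ethyl is confirmed as a 13-fold higher number from compound 2 to compound 4 (1.10 log units; beyond the scatter) and the comparison with benzyloxy on the carbonyl carbon reads a 1.4-fold higher number from compound 1 to compound 4 (0.16 log units; within the scatter) so ethyl alone stands apart among the groups shown. No measurement here explains why these numbers fall as they do.

Going by these compounds, whether the lower number belongs to ethyl alone or to small alkyl chains in general stays open. Methyl, a longer chain such as butyl, or a saturated cyclohexyl ring on this nitrogen would help to settle that.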